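Moving from 3,4-dichlorophenyl to 4-(methylsulfanyl)phenyl at the limit

The source may report more compounds than this note shows. Statements on the series, on what has been measured and on what is new or still open speak of the compounds shown alone.

In a functional assay on HL-60 cells (Homo sapiens) for antiproliferative activity, read by MTT assay, with a stated time of 72 h (on this read-out lower numbers stand for stronger inhibition and higher numbers for weaker inhibition), compound 1 `CCOc1ccc(-c2ncnn2-c2cc(OC)c(OC)c(OC)c2)cc1Cl` gives 3 nM. Compound 2 `COc1cc(-n2ncnc2-c2ccc(Cl)c(Cl)c2)cc(OC)c1OC` reads > 10000 nM, which is a limit and not a number. Compound 3 `COc1cc(-c2ncnn2-c2cccc([N+](=O)[O-])c2)cc(OC)c1OC` reads > 10000 nM, which is likewise a limit. The series therefore shows (the limit of > 10000 nM in this assay, at which 2 of the 3 values shown sit), and compound 2 has only that limit as its standing.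

Compound 4 `COc1cc(-n2ncnc2-c2ccc(SC)cc2)cc(OC)c1OC` comes from compound 2 by one change: 4-(methylsulfanyl)phenyl in place of 3,4-dichlorophenyl on an aromatic carbon. In words, 4-(methylsulfanyl)phenyl takes the place of 3,4-dichlorophenyl on an aromatic carbon of the shared core. Within the data shown here, one measured step bears on this aryl group. Chloro in place of ethoxy on an aromatic carbon gives an at least 3300-fold higher number from compound 1 to compound 2 (3.52 log units; beyond the scatter), a large step. The change to compound 4 removes both chloro groups, and a sizeable move to a lower number in this assay is expected on the strength of that step. Full recovery is not assumed, as compound 4 has neither the ethoxy nor the chloro of compound 1, and a further limit reading remains possible.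

The estimated step is an at least 50-fold lower number from compound 2 to compound 4 (1.69 log units; beyond the scatter).

For compound 4 the expected value is 200 nM, with an estimated range of 10 nM to 5000 nM.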

Compound 4, half-maximal inhibitory concentration: 500 nM
Estimate against measurement, compound 4: 2.5-fold (0.40 log units) below, within the range that was stated.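

In this assay, at this position of the shared core, 4-(methylsulfanyl)phenyl in place of 3,4-dichlorophenyl gives an at least 20-fold lower number from compound 2 to compound 4 (1.30 log units; beyond the scatter), so a reading at the limit is not fixed for this position and one change of aryl group is enough to leave it. Without the chloro or the ethoxy group of compound 1, compound 4 still gives 500 nM, which is a number and not a limit. The size of the step remains only a lower bound because compound 2 reads a limit and has no number of its own: the limit of > 10000 nM in this assay, at which 2 of the 4 values shown sit.

On these data alone, it remains open whether the reading of compound 4 belongs to the methylsulfanyl group itself or simply follows from the loss of the two chloro groups, and a 4-methoxyphenyl group or a phenyl group with a single chloro would help to separate these two readings. Also open, as far as these compounds go, is how far the sulfur group tolerates change, for example a longer chain such as ethylsulfanyl in place of methylsulfanyl, or an amine in place of the sulfur.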